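Five-membered heteroaryl on the ring nitrogen: furan to thiazole

This account rests on a few compounds, and the source may have more. Where it says the series, first, only, none or still open, it means among the compounds named here.

Measured so far in an assay on HEK293 cells for inhibition of P2X purinoceptor 7 (Homo sapiens), read by flow cytometry, with stated times of 15 min and 1 h; on this read-out higher numbers stand for weaker inhibition and lower numbers for stronger inhibition:
- compound 1, `O=C(NCc1ccc(Cl)cc1Cl)[C@@H]1CCC(=O)N1c1ccco1`: 244 nM
- compound 2, `O=C(NCc1ccc(Cl)cc1Cl)[C@@H]1CCC(=O)N1c1ccoc1`: 200 nM

Compound 2 holds the lowest of the two numbers; its nearest neighbour is compound 1, and the step of a 1.2-fold lower number from compound 1 to compound 2 (0.09 log units; within the scatter) lies within the scatter, so the two values are not distinguishable.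

Compound 3, `O=C(NCc1ccc(Cl)cc1Cl)[C@@H]1CCC(=O)N1c1cscn1`, is to be measured in this assay. It differs from compound 2 by 1,3-thiazol-4-yl in place of furan-3-yl on an amide-type nitrogen in a ring.

Going by the values given here, only one measured step bears on this site, the move of the furan attachment point from compound 1 to compound 2, and it produced no change beyond the scatter. No exchange of one heteroaryl for another has yet been measured, so there is no direct guide to the size of the present step. Compound 3 is therefore expected to stay close to compound 2, with a step of a 1.3-fold higher number from compound 2 to compound 3 (0.10 log units; within the scatter) expected within the scatter. The estimate for compound 3 is 250 nM, with a range from 100 nM to 700 nM.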

Compound 3, half-maximal inhibitory concentration: 256 nM
Compound 3: the middle estimate sits 1.0-fold (0.01 log units) below what was measured; low and high end bracket the measured number.
By their numbers in this assay, from the lowest: compounds 2, 1 and 3 (each within the scatter of the next).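

In this assay, the exchange of one heteroaryl for another on the amide-type nitrogen in a ring gives a 1.3-fold higher number from compound 2 to compound 3 (0.11 log units; within the scatter) and, against the other furan isomer, a 1.0-fold higher number from compound 1 to compound 3 (0.02 log units; within the scatter) as the second reading of this change. Both steps lie within the scatter, so all three compounds are indistinguishable, and this position accepts 1,3-thiazol-4-yl, with sulfur and a second hetero atom in its ring, as well as either furan. No supporting data give a reason for this flat result.

The compounds shown cover only five-membered aromatic rings at this position, so a six-membered ring such as phenyl or pyridine remains open. Also open, on these data alone, is how an open chain bearing an amine or a carboxylic acid would read here.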